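This account rests on a few compounds, and the source may have more. Where it says the series, first, only, none or still open, it means among the compounds named here.

Measured so far:
Compound 1 `Cc1cc(NC(=O)Nc2cc(Cl)cc(Cl)c2)c2ccccc2n1` — > 25000 nM
Compound 2 `Cc1cc(NC(=O)Nc2cccc(N(C)C)c2)c2ccccc2n1` — > 25000 nM

In an ADME assay on HEK293 cells (Homo sapiens) for cytotoxicity, with a stated time of 72 h (a higher number here means that more compound is needed for the effect, a lower number that less compound is needed), compound 2 gives > 25000 nM, which is a limit of the assay and not a number. Compound 1 likewise gives only a limit, > 25000 nM. For the measured compounds named here, both measurements sit at the limit of > 25000 nM in this assay, at which 2 of the 2 values shown sit, so no step between measured compounds can be drawn. Compound 3 `Cc1cc(NC(=O)Nc2cccc(Cl)c2)c2ccccc2n1` differs from compound 2 by chloro in place of dimethylamino on an aromatic carbon. With nothing in this assay distinguishing the two measured compounds, compound 3 is expected to sit where they do, with an expected step of a number no higher from compound 2 to compound 3 (the limit leaves the size open) no larger than the scatter. Compound 3 is thus estimated at 25000 nM, between 12000 nM and 60000 nM.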

Compound 3, half-maximal effective concentration: 21000 nM
Beside the measured number, compound 3's estimate is 1.2-fold (0.08 log units) above it; the measured number falls inside the stated range.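

For the compounds shown here, the only number among the three comes from compound 3, which in this assay gives 21000 nM. Chloro in place of dimethylamino gives an at least 1.1-fold lower number from compound 2 to compound 3 (0.07 log units; that floor lies within the scatter) and hydrogen in place of chloro gives an at least 1.1-fold lower number from compound 1 to compound 3 (0.07 log units; that floor lies within the scatter). The other two values are limits of the assay and not numbers, so the true size of either step stays unread: the limit of > 25000 nM in this assay, at which 2 of the 3 values shown sit.

Still open, as far as these compounds go, is whether a carboxylic acid or a longer chain on this aromatic carbon would move the number in this assay beyond the scatter from compound 3.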